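Aminoamino in Place of Methoxy on a Carbonyl Carbon

A few compounds are considered here, and "the series" means these few. Any claim that something is new, unique, unknown or untested is made for them only; others in the source may bear on it.

Compound 1 `C[C@H](NC(=O)c1c(Cc2cccc(Cl)c2)sc2c1CCOC2)c1ccc(C(=O)O)cc1` and compound 2 `COC(=O)c1ccc([C@H](C)NC(=O)c2c(Cc3ccc(F)cc3)sc3c2CCOC3)cc1` share a core and were both tested in a functional assay on CHO/Galpha16 cells for antagonist activity at prostaglandin E2 receptor EP4 subtype (Homo sapiens), read by calcium flux, with a stated time of 15 min; on this read-out lower numbers stand for stronger inhibition and higher numbers for weaker inhibition. In this assay compound 1 gives 3.2 nM. For compound 2 the assay reports only a limit, > 1000 nM, so no exact number is known for it. Compound 2 thus stands at the limit of > 1000 nM in this assay, at which 1 of the 2 values shown sits, the weaker end of the two values shown, whereas compound 1 lies far below that limit.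

Compound 3 `C[C@H](NC(=O)c1c(Cc2ccc(F)cc2)sc2c1CCOC2)c1ccc(C(=O)NN)cc1` is obtained from compound 2 by a single change: aminoamino in place of methoxy on a carbonyl carbon. For the measured compounds named here, no measured pair of compounds shows this change, so its effect cannot be read off from the data; it can only be estimated. Since compound 2 itself gave only a limit, a step from it is hard to size. The step from compound 2 to compound 3 is expected to be a step that the limit leaves unreadable from compound 2 to compound 3, that is, no change beyond the scatter, with compound 3 most likely remaining weak. Compound 3 is therefore estimated to give about 1500 nM in this assay, within a range from 300 nM to 8000 nM.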

Compound 3, half-maximal inhibitory concentration: 74.9 nM
For compound 3 the middle estimate is 20-fold (1.30 log units) above the measured one; the whole stated range lies above it.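

In this assay, aminoamino in place of methoxy on a carbonyl carbon attached to an aromatic carbon gives an at least 13-fold lower number from compound 2 to compound 3 (1.12 log units; beyond the scatter). This shows that the group at this one place can decide whether the compound gives a measurable inhibition on the shared core, something compound 2 alone could not show, as it gave no exact number. The change also swaps a group without hydrogen-bond donors for one that has them, and the read-out moves strongly towards inhibition, but the full size of that move stays unknown because the starting point is only a limit: the limit of > 1000 nM in this assay, at which 1 of the 3 values shown sits.

A single change cannot separate the part played by the hydrogen-bond donors from that of the nitrogen atoms themselves, or show whether the aminoamino group is special at all. Going by these compounds, an amino group or a methylamino group on the same carbonyl carbon would test this more closely, and it also remains open whether the same change would act alike on the core of compound 1, which differs from compound 3 in more than this one place.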